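This account rests on a few compounds, and the source may have more. Where it says the series, first, only, none or still open, it means among the compounds named here.

Measured so far in a functional assay (trachea) for antagonist activity, with Cavia porcellus as the target; a lower number here means a less potent compound, a higher number a more potent compound, by a factor of ten per unit of this negative logarithm:

Compound 1, `CCCCOC(=O)Nc1ccc2cnn(Cc3ccc(C(=O)NS(=O)(=O)c4ccccc4)cc3OC)c2c1`: 9.2
Compound 2, `COc1cc(C(=O)NS(=O)(=O)c2cc(C)ccc2C)ccc1Cn1ccc2ccc(NC(=O)CC3CCCC3)cc21`: 8.4
Compound 3, `CCCCC(CC)C(=O)Nc1ccc2ccn(Cc3ccc(C(=O)C(C#N)S(=O)(=O)c4ccccc4)cc3OC)c2c1`: 8.1

Among these three numbers, compound 2 stands in the middle of the range. Its value in this assay lies within the scatter of the value of compound 3, so the two cannot be told apart; against compound 1 it lies lower by a gap beyond the scatter. Going by the values given here, no pair of these measured compounds differs in a single place, so no measured single step is available to lean on.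

Compound 4, `COc1cc(C(=O)NS(=O)(=O)c2ccccc2Cl)ccc1Cn1ccc2ccc(NC(=O)CC3CCCC3)cc21`, differs from compound 2 in one place only: 2-chlorophenyl in place of 2,5-dimethylphenyl on a sulfonyl sulfur. Everything else, the shared core and the acylamino side of compound 2, is unchanged.

Among the compounds with values here, with no measured step of the same kind to rest on, the expectation is that the change alters the value by nothing beyond the scatter. Compound 4 is therefore estimated at 8.4 in this assay, in a range from 7.8 to 9. The expected step, no change at the digits printed from compound 2 to compound 4 (within the scatter), is essentially none.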

Compound 4, negative logarithm of the antagonist equilibrium constant: 9.8
The estimate for compound 4 lay 1.40 log units below the measured number, and the stated range ends below it.
By their numbers in this assay, from the lowest: compounds 3 and 2 (each within the scatter of the next); then compound 1; then compound 4.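

In this assay, 2-chlorophenyl in place of 2,5-dimethylphenyl on a sulfonyl sulfur gives a number 1.40 log units higher from compound 2 to compound 4 (beyond the scatter). Going by these compounds alone, this is the first single-place step among the measured compounds, and it shows that the number responds strongly to the group on this sulfur while the shared core and the acylamino side stay unchanged. Nothing measured here bears on why the number moved.

The one step swaps two methyl groups for a chlorine at once, so the compounds shown do not separate what the loss of either methyl or the entry of chlorine contributes. Going by these compounds, whether a 2-methylphenyl or a 2-bromophenyl on that sulfur would behave like the 2-chlorophenyl remains open, as does whether the step would carry over to the core of compound 1.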